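From a Two-Ring Aryl Group to a Chlorinated Phenyl

The source may report more compounds than this note shows. Statements on the series, on what has been measured and on what is new or still open speak of the compounds shown alone.

Two measured compounds share one core and differ only in the group on the saturated chain carbon. Compound 1 `Clc1ccc(CO/N=C/c2c(-c3ccc4ccccc4c3)nc3occn23)cc1Cl` was tested in an assay on HepG2 cells for agonist activity at nuclear receptor subfamily 1 group I member 3 (Homo sapiens), read by a luciferase reporter, with a stated time of 23 h (a higher number here means that more compound is needed for the effect, a lower number that less compound is needed), where compound 1 gives 370 nM. Compound 2 `COc1ccc(CO/N=C/c2c(-c3ccc4ccccc4c3)nc3occn23)cc1` gives 4400 nM in this assay. The step of a 12-fold higher number from compound 1 to compound 2 (1.08 log units; beyond the scatter) is the only one measured, and it leaves compound 1 with the lowest of the two numbers, its nearest neighbour being compound 2.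

Compound 3 `Clc1ccc(-c2nc3occn3c2/C=N/OCc2ccc(Cl)c(Cl)c2)cc1` keeps the dichlorinated group of compound 1 and alters the other end of the core: 4-chlorophenyl in place of naphthalen-2-yl on an aromatic carbon. Going by the values given here, no measured step touches this position; the known step of a 12-fold higher number from compound 1 to compound 2 (1.08 log units; beyond the scatter) lies on the opposite side of the molecule and says nothing direct about exchanging one aromatic group for another here. The expectation for compound 3 therefore rests on the shared core with compound 1 alone, and a moderate change in this assay is expected, most likely toward a higher number, a 2.7-fold higher number from compound 1 to compound 3 (0.43 log units; beyond the scatter). Compound 3 is estimated to give 1000 nM in this assay, with a plausible range from 250 nM to 4000 nM.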

Compound 3, half-maximal effective concentration: 410 nM
Compound 3: the middle estimate sits 2.4-fold (0.39 log units) above what was measured; measured number inside the range.
By their numbers in this assay, from the lowest: compounds 1 and 3 (each within the scatter of the next); then compound 2.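

The position on the aromatic carbon of the five-membered ring now has a measured step: 4-chlorophenyl in place of naphthalen-2-yl gives a 1.1-fold higher number from compound 1 to compound 3 (0.04 log units; within the scatter) in this assay and leaves compound 1 and compound 3 indistinguishable there. With the 3,4-dichlorophenyl group held in place, a single six-membered aromatic ring bearing chlorine therefore serves as well in this reading as the two-ring naphthalen-2-yl group, whereas the change on the saturated chain carbon gave a 12-fold higher number from compound 1 to compound 2 (1.08 log units; beyond the scatter) and lay beyond the scatter. No independent measurement is available to explain why these two groups read alike.

Going by these compounds alone, with only two groups compared at this position, the contribution of the chlorine remains open, and a plain phenyl, a 4-methoxyphenyl or a ring carrying an amine could each test it. Going by these compounds, it is also open whether the 4-chlorophenyl group would match naphthalen-2-yl in the same way when 4-methoxyphenyl replaces 3,4-dichlorophenyl at the other end of the molecule, since a step measured against one partner need not carry over to another.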